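A few compounds are considered here, and "the series" means these few. Any claim that something is new, unique, unknown or untested is made for them only; others in the source may bear on it.

Compound 3 `O=C(CN(c1ncnc2c1ncn2C1CCCCO1)C1CC1)N[C@@H](CCC(=O)OCc1ccccc1)C(=O)OCc1ccccc1` stands lowest of the three measured compounds: in a functional assay on the whole organism (Tail, strain ICR) with Mus musculus as the target, in the tail flick test, with a stated time of 90 min, at a dose of 25 umol/kg by the oral route (on this read-out lower numbers stand for a weaker effect and higher numbers for a stronger effect at the one dose given), compound 3 gives 25.2%, while compound 2 `NC(=O)CC[C@H](NC(=O)CN(c1ncnc2c1ncn2C1CCCCO1)C1CC1)C(=O)OCc1ccccc1` gives 37.8% and compound 1 `N=C(N)NCCC[C@H](NC(=O)CN(c1ncnc2c1ncn2C1CCCCO1)C1CC1)C(=O)OCc1ccccc1` gives 61.6%. Compound 4 `CC(C)C[C@H](NC(=O)CN(c1ncnc2c1ncn2C1CCCCO1)C1CC1)C(=O)OCc1ccccc1` differs from compound 3 by isopropyl in place of (benzyloxycarbonyl)methyl on a saturated chain carbon, two bonds along the chain from an amide-type nitrogen and a carbonyl carbon. Going by the values given here, the steps that bear on this site both point downward: a number 36.4 percentage points lower from compound 1 to compound 3 (beyond the scatter) and a number 12.6 percentage points lower from compound 2 to compound 3 (beyond the scatter). As far as these compounds go, none of them shows an isopropyl group at this position, so the direction of this assay for compound 4 remains open. He expects a number 6.8 percentage points higher from compound 3 to compound 4 (within the scatter), with no step beyond the scatter. His estimate for compound 4 in this assay is 32%, within a range from 12% to 55%.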

Compound 4, a percentage reported as activity, at one dose (the size of the read-out at that dose, not a potency): 28.2%
Compound 4: the middle estimate sits 3.8 percentage points above what was measured; measured number inside the range.
By their numbers in this assay, from the lowest: compounds 3, 4 and 2 (each within the scatter of the next, the first and the last beyond it); then compound 1.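

In this assay, isopropyl replaces (benzyloxycarbonyl)methyl with a number 3 percentage points higher from compound 3 to compound 4 (within the scatter), so at this place a small group with no ring and no hydrogen-bond acceptors reads like the much larger ester. Against carbamoylmethyl, the same group gives a number 9.6 percentage points lower from compound 2 to compound 4 (within the scatter), whereas the side chain of compound 1 stands apart, with a number 33.4 percentage points lower from compound 1 to compound 4 (beyond the scatter). Nothing available here accounts for these steps.

As far as these compounds go, whether a chain ending in a primary amine or a carboxylic acid would read like compound 1 or like compound 4 remains open.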